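The source may hold more compounds than are shown below. What is called first, only, known or untested is meant among the compounds shown, and "the series" means these compounds.

Measured so far in an assay on isolated protein for inhibition of DNA nucleotidylexotransferase (Homo sapiens), read by scintillation counting, with a stated time of 10 min; on this read-out higher numbers stand for weaker inhibition and lower numbers for stronger inhibition:

Compound 1 `CCOC(=O)C(=O)CC(=O)/C=C/c1cn(Cc2ccccc2)c2ccccc12` gives only a limit of the assay, > 40 uM.
Compound 2 `CCOC(=O)C(=O)CC(=O)/C=C/c1cn(Cc2ccc(Cl)cc2)c2ccccc12` gives 40 uM.
Compound 3 `O=C(/C=C/c1cn(Cc2ccccc2)c2ccccc12)CC(=O)C(=O)O` gives 7.9 uM.

On these data alone, from compound 1 to compound 2 the change is chloro in place of hydrogen on an aromatic carbon, and the step is a number no higher from compound 1 to compound 2 (the limit leaves the size open); its size stays open because of the limit of > 40 uM in this assay, at which 1 of the 3 values shown sits. From compound 1 to compound 3 the cores differ by hydrogen in place of ethyl on an oxygen next to a carbonyl group, with the step of an at least 5.0-fold lower number from compound 1 to compound 3 (0.70 log units; beyond the scatter). Compound 4 `O=C(/C=C/c1cn(Cc2ccc(Cl)cc2)c2ccccc12)CC(=O)C(=O)O` is not yet measured in this assay; it differs from compound 3 by chloro in place of hydrogen on an aromatic carbon, the same change as that from compound 1 to compound 2. Since that earlier step gave no readable size, the expected step of a 1.3-fold lower number from compound 3 to compound 4 (0.12 log units; within the scatter) is taken as small, close to no change. Compound 4 is thus estimated at 6 uM, within 2 uM to 20 uM.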

Compound 4, concentration for 50% inhibition: 10 uM
For compound 4 the middle estimate is 1.7-fold (0.22 log units) below the measured one; the range from low to high includes it.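

In this assay, chloro in place of hydrogen on the phenyl of the benzyl group gives a 1.3-fold higher number from compound 3 to compound 4 (0.10 log units; within the scatter), so this pair shows no readable effect of the change, while the step on the ethyl-bearing pair cannot be read: the same change on two cores in this assay, a number no higher (the limit leaves the size open) from compound 1 to compound 2 and a 1.3-fold higher number (0.10 log units; within the scatter) from compound 3 to compound 4; the limit leaves it open whether they differ. Hydrogen in place of ethyl carries over in the same direction, with a 4.0-fold lower number from compound 2 to compound 4 (0.60 log units; beyond the scatter) on the chloro-bearing pair, but whether its size holds from one core to the other stays undecided: the same change on two cores in this assay, an at least 5.0-fold lower number (0.70 log units; beyond the scatter) from compound 1 to compound 3 and a 4.0-fold lower number (0.60 log units; beyond the scatter) from compound 2 to compound 4; the limit leaves it open whether they differ. Compound 1 gives > 40 uM, which is a limit of the assay, and neither comparison of step sizes can be closed: the limit of > 40 uM in this assay, at which 1 of the 4 values shown sits.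

The compounds shown leave open what fluoro or methoxy in place of chloro would do. They also leave open the effect of an amide in place of the carboxylic acid.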